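Cathepsin S series: phenoxy to benzylamino on the sulfanyl chain

The source may report more compounds than this note shows. Statements on the series, on what has been measured and on what is new or still open speak of the compounds shown alone.

Measured compounds:
compound 1 `CS(=O)(=O)N1CCc2c(c(-c3ccc(C(F)(F)F)c(SCCOc4ccccc4)c3)nn2CCCN2CCC(N3CCCC3=O)CC2)C1` — 220 nM
compound 2 `CS(=O)(=O)C1CCc2c(c(-c3ccc(C(F)(F)F)c(SCCO)c3)nn2CCCN2CCC(N3CCCC3=O)CC2)C1` — 200 nM

In an assay on isolated protein for inhibition of cathepsin S (Homo sapiens) (a lower number here means a stronger inhibitor, a higher number a weaker inhibitor), compound 1 gives 220 nM. Compound 2 gives 200 nM in this assay, and the two numbers lie within the usual scatter of each other, so neither compound can be set above the other. Compound 1 carries the highest of the two numbers shown, but only by a margin within that scatter.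

Compound 3 `CS(=O)(=O)N1CCc2c(c(-c3ccc(C(F)(F)F)c(SCCNCc4ccccc4)c3)nn2CCCN2CCC(N3CCCC3=O)CC2)C1` is the next member and differs from compound 1 in one place: benzylamino in place of phenoxy on a saturated chain carbon, two bonds along the chain from a sulfur. Going by the values given here, no step between two measured compounds isolates this kind of change, so the size and direction of the step from compound 1 to compound 3 cannot be read from the series.

The expectation for compound 3 in this assay is therefore a step from compound 1 of a 1.1-fold lower number from compound 1 to compound 3 (0.04 log units; within the scatter), i.e. none beyond the scatter. Compound 3 is estimated at 200 nM, with a range from 70 nM to 600 nM.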

Compound 3, half-maximal inhibitory concentration: 700 nM
Beside the measured number, compound 3's estimate is 3.5-fold (0.54 log units) below it; the measured number lies above the stated range.
By their numbers in this assay, from the lowest: compounds 2 and 1 (each within the scatter of the next); then compound 3.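

In this assay, benzylamino in place of phenoxy on a saturated chain carbon, two bonds along the chain from a sulfur, gives a 3.2-fold higher number from compound 1 to compound 3 (0.50 log units; beyond the scatter), the first step readable at this position. The position therefore responds to the group placed there: (2-phenoxyethyl)sulfanyl and (2-(benzylamino)ethyl)sulfanyl are not interchangeable in this assay, although both carry a six-membered aromatic ring of carbon only. Benzylamino also brings a hydrogen-bond donor that phenoxy lacks, but nothing measured on these compounds bears on why the number rises.

From the compounds shown here alone, whether the step goes with the nitrogen or with the added methylene remains open, and a benzyloxy group or an anilino group on the same chain would separate the two. Also open, going by these compounds, is how an N-methylbenzylamino group, which has no hydrogen on the nitrogen, would compare with benzylamino here.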